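The source may hold more compounds than are shown below. What is called first, only, known or untested is meant among the compounds shown, and "the series" means these compounds.

Measured so far in a functional assay on HCT-116 cells (Homo sapiens) for antiproliferative activity, read by sulforhodamine B assay, with a stated time of 72 h (on this read-out lower numbers stand for stronger inhibition and higher numbers for weaker inhibition), by compound:
- compound 1 `Cn1ncc(Cl)c1-c1cc(C(=O)N[C@@H]2CN[C@H](CC(N)=O)C[C@H]2c2ccc(Cl)c(Cl)c2)oc1Cl` gives 650 nM
- compound 2 `CCC[C@@H]1C[C@@H](c2ccc(Cl)c(Cl)c2)[C@H](NC(=O)c2cc(-c3c(Cl)cnn3C)c(Cl)o2)CN1` gives 1020 nM

Among the compounds with values here, compound 2 stands level with compound 1, its only neighbour on the numbers. Compound 3 `COCC[C@@H]1C[C@@H](c2ccc(Cl)c(Cl)c2)[C@H](NC(=O)c2cc(-c3c(Cl)cnn3C)c(Cl)o2)CN1` differs from compound 2 by methoxy in place of methyl on a saturated chain carbon, two bonds along the chain from a saturated ring carbon in short, methoxy in place of methyl on a saturated chain carbon, two bonds along the chain from a saturated ring carbon. Within the data shown here, the one measured step that bears on this is a 1.6-fold higher number from compound 1 to compound 2 (0.20 log units; within the scatter) for ethyl in place of carbamoyl on that chain, so no step beyond the scatter is expected in this assay here. The expected step is a 1.3-fold lower number from compound 2 to compound 3 (0.11 log units; within the scatter) by this estimate. Compound 3 is estimated at 800 nM with an expected range from 350 nM to 1800 nM on this read-out.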

Compound 3, half-maximal inhibitory concentration: 470 nM
Compound 3: the middle estimate sits 1.7-fold (0.23 log units) above what was measured; the range from low to high includes it.
By their numbers in this assay, from the lowest: compounds 3, 1 and 2 (each within the scatter of the next, the first and the last beyond it).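

In this assay, within the data shown here, methoxy in place of methyl on a saturated chain carbon, two bonds along the chain from a saturated ring carbon, gives a 2.2-fold lower number from compound 2 to compound 3 (0.34 log units; beyond the scatter) and is the first step on this chain to clear the scatter. Methoxymethyl in place of carbamoyl gives a 1.4-fold lower number from compound 1 to compound 3 (0.14 log units; within the scatter) and so leaves compound 3 level with compound 1. No measurement on hand accounts for either step. As far as these compounds go, whether a longer ether chain keeps the gain stays open, as does the outcome for a terminal amine or carboxylic acid on this chain.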